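Methylsulfanyl in place of (2-methoxyethyl)carbamoyl: lipophilicity note

This account rests on a few compounds, and the source may have more. Where it says the series, first, only, none or still open, it means among the compounds named here.

Measured so far in a physicochemical assay for lipophilicity; on this read-out higher numbers stand for higher lipophilicity and lower numbers for lower lipophilicity:
compound 1 `O=C(N[C@@H](CO)C(=O)NO)c1ccc(C#Cc2ccccc2)cc1` gives 2
compound 2 `NC(=O)C[C@H](NC(=O)c1ccc(C#Cc2ccccc2)cc1)C(=O)NO` gives 1
compound 3 `COCCNC(=O)C[C@H](NC(=O)c1ccc(C#Cc2ccccc2)cc1)C(=O)NO` gives 2

Compound 3 stands level with compound 1 at the digits shown, the two together the highest of the three; the step of no change at the digits printed from compound 1 to compound 3 (within the scatter) lies within the scatter, whereas the step of a number 1.00 log units higher from compound 2 to compound 3 (beyond the scatter) is beyond it, as is a number 1.00 log units lower from compound 1 to compound 2 (beyond the scatter).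

Compound 4 `CSC[C@H](NC(=O)c1ccc(C#Cc2ccccc2)cc1)C(=O)NO` differs from compound 3 by methylsulfanyl in place of (2-methoxyethyl)carbamoyl on a saturated chain carbon, two bonds along the chain from an amide-type nitrogen and a carbonyl carbon. Among the compounds with values here, no measured step has methylsulfanyl entering, so none bears directly on it; the steps around compound 3 only show that the hydroxy and carbamoyl variants bracket it. Given what leaves and what enters as counted, a rise beyond the scatter is expected, a number 1.00 log units higher from compound 3 to compound 4 (beyond the scatter). Compound 4 is estimated at 3, range 2.3 to 3.7.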

Compound 4, distribution coefficient: 3
Estimate against measurement, compound 4: no gap at the digits printed; the measured number falls inside the stated range.
By their numbers in this assay, from the lowest: compound 2; then compounds 1 and 3 (each within the scatter of the next); then compound 4.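

In this assay, within the data shown here, methylsulfanyl on the saturated chain carbon is the first group to stand clear of hydroxy (a number 1.00 log units higher from compound 1 to compound 4 (beyond the scatter)) and of (2-methoxyethyl)carbamoyl (a number 1.00 log units higher from compound 3 to compound 4 (beyond the scatter)). Among these compounds, the largest step at this place so far comes against carbamoyl (a number 2.00 log units higher from compound 2 to compound 4 (beyond the scatter)). No supporting measurement accounts for these steps.

Open, going by these compounds, is how a sulfur-free group, such as methoxy or a plain ethyl chain, would compare with methylsulfanyl. Also open, on these data alone, is where a carboxylic acid or an amine would fall on this read-out.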